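This account rests on a few compounds, and the source may have more. Where it says the series, first, only, none or still open, it means among the compounds named here.

Three analogues built on one shared core have been measured so far. Compound 1 `Nc1ccccc1S(=O)(=O)N1CC(n2cnc3c(Cl)nc(Cl)nc32)OCc2ccccc21` gives 467 nM in a functional assay on MDA-MB-231 cells (Homo sapiens) for cytotoxicity, read by sulforhodamine B assay, with a stated time of 3 days; on this read-out higher numbers stand for weaker inhibition and lower numbers for stronger inhibition. Compound 2 `O=[N+]([O-])c1ccccc1S(=O)(=O)N1CC(n2cnc3c(Cl)nc(Cl)nc32)OCc2ccccc21` gives 280 nM in this assay, a move of a 1.7-fold lower number from compound 1 to compound 2 (0.22 log units; within the scatter). Compound 3 `O=[N+]([O-])c1ccc(S(=O)(=O)N2CC(n3cnc4c(Cl)nc(Cl)nc43)OCc3ccccc32)cc1` gives 166 nM in this assay, the smallest of the three numbers; its gap to compound 2 is within the scatter, whereas the move recorded as a 2.8-fold lower number from compound 1 to compound 3 (0.45 log units; beyond the scatter) clears it, and a 1.7-fold lower number from compound 2 to compound 3 (0.23 log units; within the scatter) does not.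

Compound 4 `O=S(=O)(c1ccccc1NO)N1CC(n2cnc3c(Cl)nc(Cl)nc32)OCc2ccccc21` has not yet been measured. It differs from compound 3 by 2-(hydroxyamino)phenyl in place of 4-nitrophenyl on a sulfonyl sulfur. Among the measured compounds shown here, two measured steps bear on this change. The step of a 2.8-fold lower number from compound 1 to compound 3 (0.45 log units; beyond the scatter) shows that exchanging a 2-aminophenyl for a 4-nitrophenyl gave a modestly smaller number, so a return to a phenyl carrying a nitrogen group at the 2-position would be expected to undo part of that gain. The step of a 1.7-fold lower number from compound 2 to compound 3 (0.23 log units; within the scatter) points the same way but stays within the scatter. Hydroxyamino is neither the amino of compound 1 nor the nitro of compound 2, and no measured pair shows how it compares with either. Accordingly the expected step is a 2.1-fold higher number from compound 3 to compound 4 (0.32 log units; beyond the scatter). Compound 4 is estimated at 350 nM in this assay, with a range from 150 nM to 800 nM.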

Compound 4, half-maximal inhibitory concentration: 487 nM
Estimate against measurement, compound 4: 1.4-fold (0.14 log units) below, within the range that was stated.
By their numbers in this assay, from the lowest: compounds 3, 2, 1 and 4 (each within the scatter of the next, the first and the last beyond it).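

In this assay, adding a hydroxy on the nitrogen of the 2-aminophenyl group leaves the number within the scatter (a 1.0-fold higher number from compound 1 to compound 4 (0.02 log units; within the scatter)), and hydroxyamino in place of nitro on the same aromatic carbon also stays within it (a 1.7-fold higher number from compound 2 to compound 4 (0.24 log units; within the scatter)), so the 2-aminophenyl, 2-nitrophenyl and 2-(hydroxyamino)phenyl groups on the sulfonyl sulfur cannot be told apart in this assay. The exchange of 4-nitrophenyl for 2-(hydroxyamino)phenyl, by contrast, gives a step beyond the scatter (a 2.9-fold higher number from compound 3 to compound 4 (0.47 log units; beyond the scatter)), so compound 3 now stands clear of two of the three other compounds, compound 1 and compound 4, while compound 2 remains within the scatter of all three. No measurement accompanies these numbers that could account for the differences among them.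

The compounds shown leave open whether the separation of compound 3 belongs to the nitro group itself or to where it sits, since its gap to compound 2 stays within the scatter. They also leave open how a plain phenyl, or a phenyl carrying a methoxy group or a carboxylic acid, would behave on the sulfonyl sulfur.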